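Acrylamide Tail Variation on a Quinazoline-Type Scaffold

This account rests on a few compounds, and the source may have more. Where it says the series, first, only, none or still open, it means among the compounds named here.

Measured so far:
- compound 1, `C=C(C)C(=O)Nc1cc2c(N3CCc4ccccc43)ncnc2cc1O[C@@H]1CCOC1`: 4910 nM
- compound 2, `COc1cc2ncnc(N3CCCc4ccccc43)c2cc1NC(=O)C=C(C)C`: 6130 nM

Both compounds were tested in a functional assay on PC-3 cells (Homo sapiens) for antiproliferative activity, read by MTT assay, with a stated time of 72 h; a higher number here means a weaker inhibitor, a lower number a stronger inhibitor. Compound 2 has the higher of the two numbers, but its gap to compound 1 lies within the scatter of this assay, so the two cannot be ranked against each other.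

Compound 3, `CCC/C=C/C(=O)Nc1cc2c(N3CCCc4ccccc43)ncnc2cc1OC`, has not yet been measured. It differs from compound 2 in one place: pent-1-en-1-yl in place of 2-methylprop-1-en-1-yl on a carbonyl carbon. Put plainly, pent-1-en-1-yl replaces 2-methylprop-1-en-1-yl on the carbonyl carbon of the amide. No measured pair shows the effect of this exact change, so no shown step can guide the expectation. Given how close compound 1 and compound 2 sit, a small step, likely no larger than the scatter, is expected for compound 3, with a slight lean toward a lower number, giving an estimated step of a 1.4-fold lower number from compound 2 to compound 3 (0.13 log units; within the scatter).

Compound 3 is therefore estimated at 4500 nM in this assay, with a range from 1500 nM to 13000 nM.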

Compound 3, half-maximal inhibitory concentration: 2240 nM
Beside the measured number, compound 3's estimate is 2.0-fold (0.30 log units) above it; measured number inside the range.
By their numbers in this assay, from the lowest: compound 3; then compounds 1 and 2 (each within the scatter of the next).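

Swapping 2-methylprop-1-en-1-yl for pent-1-en-1-yl on the carbonyl carbon of the amide gives a 2.7-fold lower number from compound 2 to compound 3 (0.44 log units; beyond the scatter) in this assay, the first change in one place shown here, and it shows that the number responds to the group at this position. The response is modest, and it comes from a small edit: both groups are open carbon chains with one double bond and no hydrogen-bond donors or acceptors, with 5 carbon atoms entering and 4 leaving. Nothing shown here explains why this change lowers the number.

This single pair cannot separate the effect of the added carbon from that of the different arrangement of the chain. A longer chain such as hept-1-en-1-yl, or a chain ending in a dimethylamino group, on the same carbonyl carbon would test whether the number keeps falling.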